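The source may report more compounds than this note shows. Statements on the series, on what has been measured and on what is new or still open speak of the compounds shown alone.

Three thiosemicarbazones were tested in a functional assay on HeLa cells (Homo sapiens) for cytotoxicity, read by MTT assay, with a stated time of 72 h, tested at 30 uM; on this read-out higher numbers stand for more inhibition of growth at the one concentration tested and lower numbers for less inhibition of growth. Compound 1 `N/C(=N\NC(=S)N1CCCCCC1)c1ccccn1` gives 82.9%, the highest of the three numbers. Compound 2 `N/C(=N\NC(=S)N1CCCC1)c1ccc(F)cn1` gives 81.2% in this assay, and compound 3 `N/C(=N\NC(=S)N1CCCCC1)c1ccccn1` gives 76.9%; both of these lie within the scatter of compound 1, so the three cannot be told apart on this read-out.

Compound 4 `Cc1ccnc(/C(N)=N/NC(=S)N2CCCCCC2)c1` differs from compound 1 in one place: methyl in place of hydrogen on an aromatic carbon. No comparable change is among the measured pairs, so the expectation rests only on the narrow spread of the three numbers. A step no larger than the scatter is expected, with the change from compound 1 to compound 4 estimated as a number 2.9 percentage points lower from compound 1 to compound 4 (within the scatter). Compound 4 is therefore expected to give about 80% in this assay, within a range from 65% to 92%.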

Compound 4, percent growth inhibition at one concentration: 69.9%
Estimate against measurement, compound 4: 10.1 percentage points above; measured number inside the range.
By their numbers in this assay, from the lowest: compounds 4, 3, 2 and 1 (each within the scatter of the next, the first and the last beyond it).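

Methyl in place of hydrogen on this aromatic carbon, opposite the ring nitrogen, is not a silent change: in this assay it gives a number 13 percentage points lower from compound 1 to compound 4 (beyond the scatter). Among the compounds shown here, it is the first single-place change that can be read here, and it shows that this position responds to one added carbon, although the three earlier compounds could not be told apart. Nothing shown gives a reason for this step. Open, going by these compounds, is whether a methoxy group, an amine or a longer chain at this position would act as methyl does, and whether methyl would give a similar step on the core of compound 3.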